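Amide variation across a shared core, three measured

This account rests on a few compounds, and the source may have more. Where it says the series, first, only, none or still open, it means among the compounds named here.

Compound 1 `CCCCc1nc(C)c(CC(=O)N2CCC[C@H]2C(=O)OC)c(=O)n1Cc1ccc(-c2ccccc2-c2nnn[nH]2)cc1` and compound 2 `CCCCc1nc(C)c(CC(=O)N2CCSCC2)c(=O)n1Cc1ccc(-c2ccccc2-c2nnn[nH]2)cc1` share one core and differ by thiomorpholin-4-yl in place of 2-(methoxycarbonyl)pyrrolidin-1-yl on a carbonyl carbon. In an in vivo functional assay on the whole organism for inhibition, with Rattus norvegicus as the target (a higher number here means that more compound is needed for the effect, a lower number that less compound is needed), compound 1 gives 0.043 mg/kg, and compound 2 gives 0.038 mg/kg; the step is a 1.1-fold lower number from compound 1 to compound 2 (0.05 log units; within the scatter). Compound 3 `CCCCc1nc(C)c(CCC(=O)N2CCC[C@H]2C(=O)OC)c(=O)n1Cc1ccc(-c2ccccc2-c2nnn[nH]2)cc1` differs from compound 1 by ((2-(methoxycarbonyl)pyrrolidin-1-yl)carbonyl)methyl in place of (2-(methoxycarbonyl)pyrrolidin-1-yl)carbonyl on a saturated chain carbon bound to an aromatic carbon, and in this assay compound 3 gives 0.063 mg/kg; the steps are a 1.5-fold higher number from compound 1 to compound 3 (0.17 log units; within the scatter) and a 1.7-fold higher number from compound 2 to compound 3 (0.22 log units; within the scatter). Compound 4 `CCCCc1nc(C)c(CCC(=O)N2CCSCC2)c(=O)n1Cc1ccc(-c2ccccc2-c2nnn[nH]2)cc1` has not been measured; it differs from compound 3 by thiomorpholin-4-yl in place of 2-(methoxycarbonyl)pyrrolidin-1-yl on a carbonyl carbon, the same change as between compound 1 and compound 2, at the same place. Because a 1.1-fold lower number from compound 1 to compound 2 (0.05 log units; within the scatter) stayed within the scatter, the step from compound 3 to compound 4 is expected to be about a 1.1-fold lower number from compound 3 to compound 4 (0.04 log units; within the scatter). For compound 4 the expected value in this assay is 0.057 mg/kg, estimated to lie between 0.03 mg/kg and 0.11 mg/kg.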

Compound 4, dose for half-maximal effect: 0.204 mg/kg
Compound 4: the middle estimate sits 3.6-fold (0.55 log units) below what was measured, and the stated range ends below it.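

In this assay, thiomorpholin-4-yl in place of 2-(methoxycarbonyl)pyrrolidin-1-yl on a carbonyl carbon did not carry over unchanged from one core to the other: the same change on two cores in this assay, a 1.1-fold lower number (0.05 log units; within the scatter) from compound 1 to compound 2 and a 3.2-fold higher number (0.51 log units; beyond the scatter) from compound 3 to compound 4, 3.7-fold (0.56 log units) apart, beyond the scatter of two such steps. Compound 4 also needs more compound than either compound with the shorter link, with a 5.4-fold higher number from compound 2 to compound 4 (0.73 log units; beyond the scatter) and a 4.7-fold higher number from compound 1 to compound 4 (0.68 log units; beyond the scatter), and the new step itself is a 3.2-fold higher number from compound 3 to compound 4 (0.51 log units; beyond the scatter). This rests on one pair per core, so it shows that the step differs between these two cores, but not why, nor how the change behaves on any other core.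

Open, going by these compounds, is whether the gap extends to other amides on the same core, such as morpholin-4-yl or piperidin-1-yl. Also open, on these data alone, is what a free carboxylic acid in place of the methyl ester of compound 3 would give.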